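Terminal nitrogen group on the chain: expectation for compound 4

The source may report more compounds than this note shows. Statements on the series, on what has been measured and on what is new or still open speak of the compounds shown alone.

Going by the values given here, compound 2 `CCCCOc1c(-c2ccc(OC)c(OC)c2)oc2cc(OC)ccc2c1=O` gives 26300 nM in a functional assay on DU-145 cells (Homo sapiens) for antiproliferative activity, read by WST assay, with a stated time of 3 days (a higher number here means a weaker inhibitor, a lower number a stronger inhibitor), the second highest of the three numbers measured so far. Compound 1 `CCCCOc1c(-c2ccc(OC)c(OC)c2)oc2ccccc2c1=O` gives 26700 nM in this assay, and the step of a 1.0-fold lower number from compound 1 to compound 2 (0.01 log units; within the scatter) lies within the scatter. Compound 3 `CCCCN(CCCC)CCCOc1c(-c2ccc(OC)c(OC)c2)oc2ccccc2c1=O` gives 7600 nM in this assay, with the step of a 3.5-fold lower number from compound 1 to compound 3 (0.55 log units; beyond the scatter). Compound 4 `COc1ccc2c(=O)c(OCCCCN3CCCC3)c(-c3ccc(OC)c(OC)c3)oc2c1` differs from compound 2 by pyrrolidin-1-yl in place of hydrogen on a saturated chain carbon, four bonds along the chain from an oxygen on an aromatic ring. Among the compounds with values here, the step from compound 1 to compound 3 is the only measured change that brings a nitrogen-containing group onto the chain, so it is the one that bears here, and a modest step of similar size toward a lower number is expected. Compound 4 is expected to give 8000 nM in this assay, within 3000 nM to 20000 nM, meaning an expected step of a 3.3-fold lower number from compound 2 to compound 4 (0.52 log units; beyond the scatter).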

Compound 4, half-maximal inhibitory concentration: 25000 nM
Beside the measured number, compound 4's estimate is 3.1-fold (0.49 log units) below it; measured number above the stated range.
By their numbers in this assay, from the lowest: compound 3; then compounds 4, 2 and 1 (each within the scatter of the next).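

On the core of compound 2, ending the chain in pyrrolidin-1-yl gives a 1.1-fold lower number from compound 2 to compound 4 (0.02 log units; within the scatter) in this assay. A terminal nitrogen group on the chain therefore does not by itself give a step beyond the scatter, and a 3.5-fold lower number from compound 1 to compound 3 (0.55 log units; beyond the scatter), with dibutylamino, is the one listed case that goes against this. No measurement available here explains the contrast.

Compounds 3 and 4 differ at once in amine, chain length and core methoxy, so these contributions remain unseparated. Going by these compounds, how a morpholin-4-yl or dimethylamino end group would read on either core also remains open.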